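Removing an Amide Methyl: Expected Effect on Potency

The source may report more compounds than this note shows. Statements on the series, on what has been measured and on what is new or still open speak of the compounds shown alone.

Of the compounds shown here, three have been measured in an assay on a protein complex for inhibition of CDK8/Cyclin C (Homo sapiens), with a stated time of 1 h; a higher number here means a weaker inhibitor, a lower number a stronger inhibitor. Compound 1 `CNC(=O)/C=C/c1ccncc1-c1ccc2ccccc2c1` is the strongest inhibitor of the three, giving 12.4 nM. Compound 2 `CCOC(=O)/C=C/c1ccncc1-c1ccc2c(cnn2C)c1` gives 102 nM, and compound 3 `CN1CCN(C(=O)/C=C/c2ccncc2-c2ccc(F)cc2)CC1` gives 1210 nM; both of these lie well beyond the scatter from compound 1. Compound 4 `NC(=O)/C=C/c1ccncc1-c1ccc2ccccc2c1` has not been measured yet. It differs from compound 1 in one place: hydrogen in place of methyl on an amide-type nitrogen. For the measured compounds named here, no measured pair shows this same change, so its effect cannot be read from the data. Only a small step is expected in this assay, in no clear direction; the estimate corresponds to a 1.3-fold higher number from compound 1 to compound 4 (0.11 log units; within the scatter). Compound 4 is therefore expected to give about 16 nM, with a likely range from 5 nM to 50 nM.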

Compound 4, half-maximal inhibitory concentration: 10.5 nM
Beside the measured number, compound 4's estimate is 1.5-fold (0.18 log units) above it, within the range that was stated.
By their numbers in this assay, from the lowest: compounds 4 and 1 (each within the scatter of the next); then compound 2; then compound 3.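

In this assay, hydrogen can replace the methyl on the amide-type nitrogen of compound 1 with only a 1.2-fold lower number from compound 1 to compound 4 (0.07 log units; within the scatter). For the compounds shown here, this pair is the first to isolate this position, and it shows that, on this core, the methyl is not needed to keep the potency. No measurement here explains this result.

Going by these compounds, whether this nitrogen would also accept an ethyl group or a longer chain ending in an amine remains open. So does whether the same swap would behave alike on a core other than that of compound 1.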